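The source may hold more compounds than are shown below. What is called first, only, known or untested is meant among the compounds shown, and "the series" means these compounds.

Four compounds built on one shared core are compared in a functional assay on A549 cells (Homo sapiens) for inhibition, read by MTT assay, with a stated time of 72 h; on this read-out higher numbers stand for weaker inhibition and lower numbers for stronger inhibition. Compound 1 `O=C(Nc1ccc(Oc2ccnc3[nH]ccc23)cc1)c1cn(-c2ccc(Cl)cc2)c2ccccc2c1=O` gives 650 nM in this assay. Compound 2 `O=C(Nc1ccc(Oc2ccnc3[nH]ccc23)cc1)c1cn(-c2ccc(Br)cc2)c2ccccc2c1=O` gives 450 nM, and compound 3 `O=C(Nc1ccc(Oc2ccnc3[nH]ccc23)c(F)c1)c1cn(-c2ccc(Cl)cc2)c2ccccc2c1=O` gives 320 nM. Compound 4 `O=C(Nc1ccc(Oc2ccnc3[nH]ccc23)c(F)c1)c1cn(-c2ccc(Br)cc2)c2ccccc2c1=O` has not yet been measured in this assay.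

Compound 1 and compound 2 differ by bromo in place of chloro on an aromatic carbon, a change that gave a 1.4-fold lower number from compound 1 to compound 2 (0.16 log units; within the scatter). Compound 1 and compound 3 differ by fluoro in place of hydrogen on an aromatic carbon, and this gave a 2.0-fold lower number from compound 1 to compound 3 (0.31 log units; beyond the scatter). Of the three measured compounds, compound 3 has the lowest number, but its gap to compound 2 lies within the scatter, so only its gap to compound 1 can be called a real difference.

Compound 4 differs from compound 3 by bromo in place of chloro on an aromatic carbon. This is the same change as that between compound 1 and compound 2, made on a core that instead carries the fluoro described above; the surroundings of the place of exchange are the same in both pairs. Since the earlier exchange gave a step within the scatter, a step of about the same size, a 1.4-fold lower number from compound 3 to compound 4 (0.14 log units; within the scatter), is expected from compound 3 to compound 4, because compound 3 stands at 320 nM and the earlier pair moved only by a 1.4-fold lower number from compound 1 to compound 2 (0.16 log units; within the scatter). Compound 4 is therefore estimated to give about 230 nM in this assay, most likely between 120 nM and 450 nM.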

Compound 4, half-maximal inhibitory concentration: 950 nM
Estimate against measurement, compound 4: 4.1-fold (0.62 log units) below; the whole stated range lies below it.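

In this assay, bromo in place of chloro did not carry over from one core to the other, giving a 3.0-fold higher number from compound 3 to compound 4 (0.47 log units; beyond the scatter), and the step on the fluoro-bearing core differs from the earlier one: the same change on two cores in this assay, a 1.4-fold lower number (0.16 log units; within the scatter) from compound 1 to compound 2 and a 3.0-fold higher number (0.47 log units; beyond the scatter) from compound 3 to compound 4, 4.3-fold (0.63 log units) apart, beyond the scatter of two such steps Read the other way round, fluoro in place of hydrogen gave a 2.1-fold higher number from compound 2 to compound 4 (0.32 log units; beyond the scatter), so this change, too, behaved differently once the 4-chlorophenyl had become a 4-bromophenyl: the same change on two cores in this assay, a 2.0-fold lower number (0.31 log units; beyond the scatter) from compound 1 to compound 3 and a 2.1-fold higher number (0.32 log units; beyond the scatter) from compound 2 to compound 4, 4.3-fold (0.63 log units) apart, beyond the scatter of two such steps Both comparisons rest on the same four compounds and so describe a single interaction between the two places, which shows that in this series neither change can be treated as a fixed step, but does not show why the two changes fail to add up or how far this extends beyond these compounds.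

The compounds shown leave open whether this interaction is tied to bromo alone or also appears with iodo or a methyl group in its place on the same phenyl ring. They also leave open whether a chloro or a methoxy group in place of the fluoro would couple to the halogen on the phenyl ring in the same way.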